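Isopropyl for amino on a sulfonamide thiazole inhibitor

This account rests on a few compounds, and the source may have more. Where it says the series, first, only, none or still open, it means among the compounds named here.

Measured in an assay on isolated protein for inhibition of kynurenine 3-monooxygenase (Rattus norvegicus); on this read-out higher numbers stand for weaker inhibition and lower numbers for stronger inhibition:
compound 1 `Nc1ccc(S(=O)(=O)Nc2nc(-c3cccc([N+](=O)[O-])c3)cs2)cc1` gives 40 nM
compound 2 `O=C(O)CCC(=O)c1cccc([N+](=O)[O-])c1` gives 5770 nM

Compound 1 stands at the lowest of the two numbers. Compound 2, a short keto acid carrying the same nitrophenyl part, gives a far higher number, and the gap between the two lies beyond the usual scatter of this assay. The two compounds differ in more than one place, so no single step can be read from them.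

Compound 3 `CC(C)c1ccc(S(=O)(=O)Nc2nc(-c3cccc([N+](=O)[O-])c3)cs2)cc1` differs from compound 1 in one place: isopropyl in place of amino on an aromatic carbon. For the measured compounds named here, no measured pair shows a change of this kind, so its direction is not known from the data. The expectation is a modest step from compound 1 to compound 3 toward a somewhat higher number, a 2.0-fold higher number from compound 1 to compound 3 (0.30 log units; within the scatter), roughly at the edge of the scatter. Compound 3 is therefore estimated at 80 nM in this assay, with a range from 15 nM to 400 nM.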

Compound 3, half-maximal inhibitory concentration: 990 nM
Compound 3: middle estimate off by 12-fold (1.09 log units), on the low side; the whole stated range lies below it.
By their numbers in this assay, from the lowest: compound 1; then compound 3; then compound 2.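

In this assay, replacing amino with isopropyl on the aromatic carbon para to a large group gives a 25-fold higher number from compound 1 to compound 3 (1.39 log units; beyond the scatter) and so shows that this position is sensitive to the group it carries, something the earlier pair, differing in more than one place, could not reveal. The change swaps one heavy atom for three and removes the hydrogen-bond donor and acceptor counted for amino, so several features shift together in this single step. No available measurement explains the rise in the number.

The compounds shown leave open whether the higher number comes from losing amino or from adding isopropyl. Methyl, hydroxyl or dimethylamino in the same place would help separate these two readings.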